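Shortening the Amine Arm of Compound 1

The source may hold more compounds than are shown below. What is called first, only, known or untested is meant among the compounds shown, and "the series" means these compounds.

Compound 1, `CCN(CC)Cc1ccc2nc(NC(=O)N/N=C/c3cn(Cc4ccc(Cl)cc4Cl)c4ccccc34)sc2c1`: 3280 nM
Compound 2, `CCN(CC)Cc1ccc2nc(NC(=O)N/N=C/c3cn(Cc4ccccc4)c4ccccc34)sc2c1`: 1470 nM

Of the compounds shown here, two have been measured in a functional assay on MDA-MB-231 cells (Homo sapiens) for cytotoxicity, read by MTT assay, with a stated time of 72 h; on this read-out higher numbers stand for weaker inhibition and lower numbers for stronger inhibition. Compound 1, with 3280 nM, stands at the highest of the two numbers, that is, it is the weaker of the pair. For the measured compounds named here, the single measured step, a 2.2-fold lower number from compound 1 to compound 2 (0.35 log units; beyond the scatter), came from a change at the other end of the molecule: phenyl in place of 2,4-dichlorophenyl on a saturated chain carbon bound to an aromatic nitrogen.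

Compound 3, `CN(C)Cc1ccc2nc(NC(=O)N/N=C/c3cn(Cc4ccc(Cl)cc4Cl)c4ccccc34)sc2c1`, keeps the 2,4-dichlorophenyl group of compound 1 and instead alters the amine: dimethylamino in place of diethylamino on a saturated chain carbon bound to an aromatic carbon. Going by the values given here, no measured step touches this amine, so the one step known offers no direct guide; the shared core, the urea linker and the dichlorophenyl group are all unchanged. With nothing to point either way, the expected result is a step within the usual scatter, a 1.1-fold lower number from compound 1 to compound 3 (0.04 log units; within the scatter), with compound 3 staying near compound 1. Compound 3 is therefore estimated at 3000 nM in this assay, in a range from 1200 nM to 7500 nM.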

Compound 3, half-maximal inhibitory concentration: 1410 nM
For compound 3 the middle estimate is 2.1-fold (0.33 log units) above the measured one; the measured number falls inside the stated range.
By their numbers in this assay, from the lowest: compounds 3 and 2 (each within the scatter of the next); then compound 1.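

In this assay, the amine arm proves to be a position that responds to change: dimethylamino in place of diethylamino gives a 2.3-fold lower number from compound 1 to compound 3 (0.37 log units; beyond the scatter) and takes the group from 5 heavy atoms to 3, with the same counts of hydrogen-bond donors and acceptors and no net charge on either group. For the compounds shown here, the step is modest but beyond the scatter, so a lower number can be reached from compound 1 at this end of the molecule as well as at the 2,4-dichlorophenyl end, where the earlier change gave a 2.2-fold lower number from compound 1 to compound 2 (0.35 log units; beyond the scatter) and was the only step known. No measurement shown here explains why the smaller amine goes with the lower number.

As far as these compounds go, with only two amines compared, a single step cannot establish a trend, so it remains open whether a pyrrolidine, a morpholine or an unsubstituted amine on the same chain carbon would lower the number further or raise it. From the compounds shown here alone, it is also open whether dimethylamino and a plain phenyl together would add up, since each change has been read only on its own against compound 1.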